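Compound 3: An Ethyl Group on the Aromatic Nitrogen

The compounds below may be only part of what the source reports. "The series", "measured", "known", "first", "only" and "open" are said of these compounds alone.

Measured so far in a physicochemical assay for solubility, in phosphate buffer, at pH 7.4; a higher number here means a more soluble compound, a lower number a less soluble compound:
- Compound 1 `CC(C)Cn1cc(-c2ccnc3[nH]c(C4CCN(CC(=O)N(C)C)CC4)cc23)ccc1=O`: 390000 nM
- Compound 2 `CN(C)C(=O)CN1CCC(c2cc3c(-c4ccc(=O)n(C5CCOCC5)c4)ccnc3[nH]2)CC1`: 840000 nM

Among the compounds with values here, of these two numbers, compound 2 holds the higher one, and compound 1 is its only neighbour. The next compound, compound 3 `CCn1cc(-c2ccnc3[nH]c(C4CCN(CC(=O)N(C)C)CC4)cc23)ccc1=O`, has ethyl in place of oxan-4-yl on an aromatic nitrogen. Within the data shown here, one measured step bears on this change, since it concerns the same aromatic nitrogen: a 2.2-fold higher number from compound 1 to compound 2 (0.33 log units; beyond the scatter). That step was modest but beyond the scatter. Ethyl, like the isobutyl of compound 1, carries no ring, so a modest move towards that lower value of 390000 nM is expected, though it may stay within the scatter. The expected change is a 1.5-fold lower number from compound 2 to compound 3 (0.18 log units; within the scatter). For compound 3 the estimate is 560000 nM, with an expected range of 250000 nM to 1200000 nM.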

Compound 3, solubility: > 1000000 nM
Compound 3 was reported as a limit; the forecaster's own chance of this, stated with the estimate: 5%; at least 1.7-fold (0.25 log units) between middle value and limit.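

Compound 3 is reported in this assay only as a limit, > 1000000 nM. Ethyl in place of isobutyl gives an at least 2.5-fold higher number from compound 1 to compound 3 (0.40 log units; beyond the scatter), so a group with no ring on this aromatic nitrogen can stand well clear of compound 1, and the oxan-4-yl ring of compound 2 is not needed for a high reading. Ethyl in place of oxan-4-yl gives an at least 1.1-fold higher number from compound 2 to compound 3 (0.07 log units; that floor lies within the scatter), and since that floor lies within the scatter, the order of these two compounds stays unsettled, with the reading capped as follows: the limit of > 1000000 nM in this assay, at which 1 of the 3 values shown sits.

From the compounds shown here alone, how far compound 3 lies past its limit remains open. Also open, going by these compounds, is whether a methyl group, a longer chain or a chain carrying an amine on this nitrogen would read like ethyl or like isobutyl.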